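The source may report more compounds than this note shows. Statements on the series, on what has been measured and on what is new or still open speak of the compounds shown alone.

Compound 1 `N#Cc1c(Nc2nccs2)nc(SCc2nc3ccccc3[nH]2)nc1-c1ccccc1`: 5.81 nM
Compound 2 `N#Cc1c(NNC(N)=S)nc(SCc2nc3ccccc3[nH]2)nc1-c1ccccc1`: 3 nM

Within the data shown here, in a functional assay on SK-OV-3 cells (Homo sapiens) for cytotoxicity, read by MTT assay, with a stated time of 3 days (on this read-out lower numbers stand for stronger inhibition and higher numbers for weaker inhibition), compound 2, at 3 nM, stands level with compound 1, the only other compound measured. Compound 3 `N#Cc1c(-c2ccccc2)nc(SCc2nc3ccccc3[nH]2)nc1N1CCNCC1` differs from compound 2 by a group of 6 heavy atoms (4 carbon, 2 nitrogen; one six-membered non-aromatic ring with 2 hetero atoms) in place of a group of 5 heavy atoms (1 carbon, 3 nitrogen, 1 sulfur; no ring), on an aromatic carbon, with piperazin-1-yl entering on an aromatic carbon. Among the measured compounds shown here, one measured step bears on this, an exchange of the same group that compound 3 alters: a 1.9-fold lower number from compound 1 to compound 2 (0.29 log units; within the scatter). That single step gives no sign of a large shift, so no change beyond the scatter is expected. The expected step is a 1.7-fold higher number from compound 2 to compound 3 (0.22 log units; within the scatter). For compound 3 the estimate is 5 nM, with an expected range from 1.5 nM to 20 nM.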

Compound 3, half-maximal inhibitory concentration: 2.63 nM
The estimate for compound 3 lay 1.9-fold (0.28 log units) above the measured number, within the range that was stated.
By their numbers in this assay, from the lowest: compounds 3, 2 and 1 (each within the scatter of the next, the first and the last beyond it).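

In this assay, piperazin-1-yl, a non-aromatic ring, holds the level at this position on the aromatic carbon, with a 1.1-fold lower number from compound 2 to compound 3 (0.06 log units; within the scatter) inside the scatter. Against the (1,3-thiazol-2-yl)amino group the exchange gives a 2.2-fold lower number from compound 1 to compound 3 (0.34 log units; beyond the scatter) and this modest step is the only one among these compounds beyond the scatter, while compound 2 stays within the scatter of both others. No measurement shown here accounts for these numbers. As far as these compounds go, whether a morpholine ring or an open-chain dimethylamino group at this position would hold the same level remains open.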